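Configuration change at two ring carbons of compound 1

The source may report more compounds than this note shows. Statements on the series, on what has been measured and on what is new or still open speak of the compounds shown alone.

In an ADME assay on Caco-2 cells (Homo sapiens) for permeability, read by LC-MS, in the apical to basolateral direction, with a stated time of 60 min, at pH 6.5 (on this read-out lower numbers stand for lower permeability and higher numbers for higher permeability), compound 1 (`CC(C)(C)[C@@H](O)C(=O)N1C[C@@H]2C[C@@H]2[C@H]1C(=O)NCc1cc(Cl)ccc1-n1cnnn1`) gives 17 10^-6 cm/s and compound 2 (`CC(C)(C)C[C@@H](O)C(=O)N1C[C@@H]2C[C@@H]2[C@H]1C(=O)NCc1cc(Cl)ccc1-n1cnnn1`) gives 25 10^-6 cm/s on the same read-out. These two values lie within the scatter of each other and compound 1 holds no separate rank. The change from compound 1 to the unmeasured compound 3 (`CC(C)(C)[C@@H](O)C(=O)N1C[C@H]2C[C@H]2[C@H]1C(=O)NCc1cc(Cl)ccc1-n1cnnn1`) is the two compounds have the same atoms and bonds and differ only in configuration as drawn: 2 of 4 stereo elements differ; a stereocentre at a saturated ring carbon is drawn R in compound 1 and S in compound 3; a stereocentre at a saturated ring carbon is drawn S in compound 1 and R in compound 3 and no atom or bond leaves or enters.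

Going by the values given here, the only measured step is a 1.5-fold higher number from compound 1 to compound 2 (0.17 log units; within the scatter) and it concerns neopentyl in place of tert-butyl on a saturated chain carbon, not the ring carbons at issue here. Among the compounds with values here, no measured pair differs in configuration alone, and the data give no direct size for such a change. Within the data shown here, with that single step from compound 1 as the only guide, no shift beyond the scatter is expected in this assay and no direction is favoured. The estimate for this change is no change at the digits printed from compound 1 to compound 3 (within the scatter) with a wide margin kept for the missing evidence. For compound 3 the estimated value is 17 10^-6 cm/s with an expected range from 8 10^-6 cm/s to 35 10^-6 cm/s on this read-out.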

Compound 3, apparent permeability: 3.8 10^-6 cm/s
Compound 3: middle estimate off by 4.5-fold (0.65 log units), on the high side; the measured number lies below the stated range.
By their numbers in this assay, from the lowest: compound 3; then compounds 1 and 2 (each within the scatter of the next).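

In this assay, the configuration at these two ring carbons is a position where the number shifts, with a 4.5-fold lower number from compound 1 to compound 3 (0.65 log units; beyond the scatter). Among the steps shown, the chain change stays within the scatter, at a 1.5-fold higher number from compound 1 to compound 2 (0.17 log units; within the scatter), so this is the only step beyond the scatter and the first sign that the drawn configuration of the shared core matters on this read-out. The shift can be assigned to configuration as such and not to any group, because no atom or bond leaves or enters: the fact that compounds 1 and 3 differ only in the configuration as drawn

The two ring carbons change together in compound 3. As far as these compounds go, the share of each one stays open. Also open, from the compounds shown here alone, is whether the same configuration change gives a step of similar size with neopentyl in place of tert-butyl as in compound 2, or with a longer chain, an amine or a carboxylic acid on the chain carbon that carries the hydroxyl.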